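Adding a second chloro to the aryl of compound 3

A few compounds are considered here, and "the series" means these few. Any claim that something is new, unique, unknown or untested is made for them only; others in the source may bear on it.

Three compounds of this series have been run in a functional assay on CAKI-1 cells (Homo sapiens) for inhibition, read by sulforhodamine B assay, with a stated time of 48 h; on this read-out lower numbers stand for stronger inhibition of growth and higher numbers for weaker inhibition of growth. Compound 1 `N#C/C(=C\N1CCN(C(=O)c2ccco2)C1=S)C(=O)Nc1ccc(Cl)cc1` gives 13200 nM, compound 2 `N#C/C(=C\N1CCN(C(=O)c2ccco2)C1=S)C(N)=O` gives 11800 nM, and compound 3 `O=CN1CCN(c2ccc(Cl)cc2)C1=S` gives 14000 nM. Compound 3 carries the highest of the three numbers, but its distance to compound 1 and to compound 2 lies within the scatter, so the three stand together. Going by the values given here, the one single-point step recorded, a 1.1-fold lower number from compound 1 to compound 2 (0.05 log units; within the scatter), replaces the 4-chlorophenyl by hydrogen and moves nothing beyond the scatter.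

Compound 4 `O=CN1CCN(c2ccc(Cl)c(Cl)c2)C1=S` differs from compound 3 by chloro in place of hydrogen on an aromatic carbon. Among the compounds with values here, no measured step touches an aromatic chloro directly, and the only step available, from compound 1 to compound 2, removed the whole chlorophenyl without a change beyond the scatter. With that in view, no move beyond the scatter is expected here either. For compound 4 the expected result is a step of a 1.3-fold lower number from compound 3 to compound 4 (0.10 log units; within the scatter) in this assay, within the usual spread of repeats. Compound 4 is therefore estimated at 11000 nM, with a range from 4000 nM to 30000 nM.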

Compound 4, concentration for 50% growth inhibition: 14900 nM
The estimate for compound 4 lay 1.4-fold (0.13 log units) below the measured number, and the stated range covers the measured number.
By their numbers in this assay, from the lowest: compounds 2, 1, 3 and 4 (each within the scatter of the next).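

Chloro in place of hydrogen on this aromatic carbon, ortho to a chloro group and meta to a group of 8 heavy atoms, gives a 1.1-fold higher number from compound 3 to compound 4 (0.03 log units; within the scatter) in this assay. The earlier step removed the whole 4-chlorophenyl, whereas this one changes a single atom on the six-membered aromatic ring, and it shows that this carbon can carry a second chloro without any shift beyond the scatter. No evidence is available that would account for this flat result.

Going by these compounds, whether a different group on this same carbon, such as an amine, a carboxylic acid or a longer chain like n-butyl, would shift the number beyond the scatter remains open. Also open, on these data alone, is whether chloro on the other carbons of the ring would behave as it does here, and whether any change to the shared core would separate these compounds, all of whose values so far stand within the scatter of one another.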